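Swapping a Bromine for a Methyl on the Fused Ring

The source may hold more compounds than are shown below. What is called first, only, known or untested is meant among the compounds shown, and "the series" means these compounds.

Of the compounds shown here, three sharing one core have been tested in an ADME assay on HEK293 cells (Homo sapiens) for cytotoxicity, read by MTT assay; a higher number here means a weaker inhibitor, a lower number a stronger inhibitor. Compound 1 `COc1ccc(-n2ncn(Cc3cn(Cc4cc5cc(Br)ccc5nc4Cl)nn3)c2=O)cc1` gives 333 ug/mL, the lowest of the three numbers. Compound 2 `O=c1n(Cc2cn(Cc3cc4ccc(Cl)cc4nc3Cl)nn2)cnn1-c1ccccc1` gives 869 ug/mL, and compound 3 `O=c1n(Cc2cn(Cc3cc4cc(Br)ccc4nc3Cl)nn2)cnn1-c1ccccc1` gives 1650 ug/mL. Within the data shown here, the one change that can be followed step by step is a 5.0-fold higher number from compound 1 to compound 3 (0.70 log units; beyond the scatter), so removing the methoxy from the phenyl group raised the number clearly. Compound 2 and compound 3 differ from one another in the halogen and where it sits on the fused ring; their two values differ by less than that methoxy step.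

Compound 4 `COc1ccc(-n2ncn(Cc3cn(Cc4cc5cc(C)ccc5nc4Cl)nn3)c2=O)cc1` keeps the methoxy of compound 1 and changes only the fused ring: methyl in place of bromo on an aromatic carbon. Among the measured compounds shown here, no measured step touches this particular swap, so there is no direct guide to its effect in this assay. The closest hint, the modest gap between compound 2 and compound 3, suggests that changes on the fused ring matter less than the methoxy step. A step of a 1.2-fold higher number from compound 1 to compound 4 (0.08 log units; within the scatter) is therefore expected, within the usual scatter. Compound 4 is estimated at 400 ug/mL, with a likely range from 180 ug/mL to 900 ug/mL.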

Compound 4, half-maximal inhibitory concentration: 615 ug/mL
Compound 4: middle estimate off by 1.5-fold (0.19 log units), on the low side; measured number inside the range.
By their numbers in this assay, from the lowest: compounds 1, 4, 2 and 3 (each within the scatter of the next, the first and the last beyond it).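

In this assay, methyl in place of bromo on an aromatic carbon of the fused ring system gives a 1.8-fold higher number from compound 1 to compound 4 (0.27 log units; within the scatter). With the methoxy kept, this exchange of one heavy atom for another therefore leaves the number within the usual scatter of repeated measurements, whereas removing the methoxy gives a 5.0-fold higher number from compound 1 to compound 3 (0.70 log units; beyond the scatter), which lies beyond it. Nothing available explains the size of either step.

Bromo and methyl are the only two groups compared directly at this carbon, so the effect of an amine, a carboxylic acid or a longer chain there remains open. On these data alone, it also remains open whether the same swap would give a similar step in a compound with hydrogen in place of the methoxy on the phenyl group.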